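A few compounds are considered here, and "the series" means these few. Any claim that something is new, unique, unknown or untested is made for them only; others in the source may bear on it.

Of the compounds shown here, three have been measured in an assay on isolated protein for inhibition of ribosomal protein S6 kinase alpha-1 (Homo sapiens), read by mobility shift assay, tested at 30 uM; on this read-out higher numbers stand for more inhibition at the one concentration tested (going by the name of the read-out) and lower numbers for less inhibition. Compound 1 `COCCNc1nc(C)cc2c1c(N)nn2C` gives -4%, compound 2 `COCCNc1nc(-c2ccccc2)cc2c1c(N)nn2C` gives -3%, and compound 3 `Cc1cc2nc(-c3ccccc3)nc(N)c2c(=O)[nH]1` gives 14%, the highest of the three numbers. Compound 2 and compound 1 differ by methyl in place of phenyl on an aromatic carbon, and this change gives a number 1 percentage points lower from compound 2 to compound 1 (within the scatter) in this assay. How the core of compound 3 differs from that of compound 2 is not broken down here.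

Compound 4 `Cc1nc(N)c2c(=O)[nH]c(C)cc2n1` has not yet been measured. It differs from compound 3 by methyl in place of phenyl on an aromatic carbon. This is the same kind of change as from compound 2 to compound 1, though the surroundings differ: in compound 1 the methyl sits on a ring with 1 nitrogen, next to the ring nitrogen and meta to a (2-methoxyethyl)amino group, whereas in compound 4 it sits on a ring with 2 nitrogen, between two ring nitrogen atoms and meta to an amino group. Because the earlier change gave a number 1 percentage points lower from compound 2 to compound 1 (within the scatter), a step within the scatter, the step for compound 4 is expected to be a number 4 percentage points lower from compound 3 to compound 4 (within the scatter) in this assay. Compound 4 is therefore estimated at 10% in this assay, between -6% and 24%.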

Compound 4, a percentage reported as inhibition, at one concentration (the size of the read-out at that concentration, not a potency): -23%
Compound 4: the middle estimate sits 33 percentage points above what was measured; measured number below the stated range.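

In this assay, methyl in place of phenyl on an aromatic carbon gives a number 37 percentage points lower from compound 3 to compound 4 (beyond the scatter), and this step does not match the one seen on the other core: the same change on two cores in this assay, a number 1 percentage points lower (within the scatter) from compound 2 to compound 1 and a number 37 percentage points lower (beyond the scatter) from compound 3 to compound 4, 36 percentage points apart, beyond the scatter of two such steps The size of this change therefore did not carry over between the two cores in this series, so a step read on the core of compound 2 was no reliable guide to the same step on the core of compound 3. This does not show why the two cores respond so differently, and two pairs cannot say how the same change would behave on any further core.

The compounds shown leave open how other groups on this aromatic carbon, such as a carboxylic acid or a longer alkyl chain, would read on either core. They also leave open whether the phenyl ring of compound 3 would keep its number if it carried a substituent such as a methoxy group.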